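Removing a Nitro Group: What to Expect for Compound 3

The compounds below may be only part of what the source reports. "The series", "measured", "known", "first", "only" and "open" are said of these compounds alone.

Compound 1 `N#C[Se]c1ccc(NC(=O)OCc2ccc([N+](=O)[O-])cc2)cc1` and compound 2 `N#C[Se]c1ccc(NC(=O)Oc2ccc(F)cc2)cc1` share the same core and were each tested in a functional assay on HT-29 cells (Homo sapiens) for cytotoxicity, read by MTT assay, with a stated time of 72 h; a lower number here means a stronger inhibitor of growth, a higher number a weaker inhibitor of growth. In this assay compound 1 gives 22400 nM, the highest of the two numbers seen. Compound 2 gives 8800 nM, and the gap between the two lies beyond the usual scatter of repeated runs, so compound 1 is the weaker growth inhibitor of the pair. Compound 3 `N#C[Se]c1ccc(NC(=O)OCc2ccccc2)cc1` has not yet been measured. It differs from compound 1 in one place only: hydrogen in place of nitro on an aromatic carbon. Going by the values given here, no pair of measured compounds shows this same change, so nothing here tells directly how large a step it brings. The two measured compounds differ in a different part of the molecule, and their gap is the only hint of how much a single change can move the number. The step from compound 1 to compound 3 is expected to be modest, a 1.5-fold lower number from compound 1 to compound 3 (0.17 log units; within the scatter), and may well stay within the scatter. Compound 3 is therefore estimated at about 15000 nM, with a plausible range from 5000 nM to 45000 nM.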

Compound 3, concentration for 50% growth inhibition: 13300 nM
Estimate against measurement, compound 3: 1.1-fold (0.05 log units) above, within the range that was stated.
By their numbers in this assay, from the lowest: compounds 2, 3 and 1 (each within the scatter of the next, the first and the last beyond it).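

In this assay, going by these compounds alone, putting hydrogen in place of nitro on this aromatic carbon, para to a large group, gives a 1.7-fold lower number from compound 1 to compound 3 (0.23 log units; within the scatter), the first direct reading of this change at this position. The step stays within the scatter, so the nitro group is not needed for the growth inhibition seen here: without it, compound 3 still gives 13300 nM, and the loss of the whole group leaves no clear mark on the number. Nothing at hand bears on why the step is so small.

Within the data shown here, this is one change at one position, so it shows only that the nitro group and hydrogen cannot be told apart here, not that this carbon tolerates any group. As far as these compounds go, whether an amine, a carboxylic acid or a methoxy group on the same carbon would also stay within the scatter remains open, as does whether the same swap would give a step of similar size on a compound with a different group elsewhere in the molecule.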